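Furan-2-yl in Place of 4-(dimethylamino)phenyl on the Saturated Carbon

This account rests on a few compounds, and the source may have more. Where it says the series, first, only, none or still open, it means among the compounds named here.

Three compounds sharing one core, compound 1 `O=C1N=C(C2C(=O)c3ccccc3C2=O)CC(c2ccccc2)N1`, compound 2 `COc1ccc(C2CC(C3C(=O)c4ccccc4C3=O)=NC(=O)N2)cc1` and compound 3 `CN(C)c1ccc(C2CC(C3C(=O)c4ccccc4C3=O)=NC(=O)N2)cc1`, have been examined in a functional assay on the whole organism for inhibition, with Rattus norvegicus as the target, read by paw edema, with stated times of 30 min and 1 h, at a dose of 10 mg/kg by the oral route; a lower number here means less inhibition, a higher number more inhibition at the dose given (going by the name of the read-out). Compound 1 gives 20%, compound 2 gives 22%, and compound 3 gives 15%. Compound 3 sits at the low end of these three numbers, but the steps of a number 5 percentage points lower from compound 1 to compound 3 (within the scatter) and a number 7 percentage points lower from compound 2 to compound 3 (within the scatter) are both within the scatter, as is a number 2 percentage points higher from compound 1 to compound 2 (within the scatter), so the three numbers do not separate from one another. Compound 4, `O=C1N=C(C2C(=O)c3ccccc3C2=O)CC(c2ccco2)N1`, has not yet been measured in this assay. It differs from compound 3 by furan-2-yl in place of 4-(dimethylamino)phenyl on a saturated ring carbon. Among the compounds with values here, no measured step exchanges the whole aromatic group on this saturated ring carbon; the measured steps only vary a group on an aromatic carbon of the 4-(dimethylamino)phenyl that now leaves, and none of them moved the read-out beyond the scatter. The expectation for compound 4 is therefore a step of a number 3 percentage points higher from compound 3 to compound 4 (within the scatter), not beyond the scatter. Compound 4 is estimated at 18%, within a range from 5% to 35%.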

Compound 4, a percentage reported as inhibition, in the whole organism at one dose (the size of the read-out at that dose, not a potency): 18%
Estimate against measurement, compound 4: no gap at the digits printed; low and high end bracket the measured number.
By their numbers in this assay, from the lowest: compounds 3, 4, 1 and 2 (each within the scatter of the next).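

In this assay, within the data shown here, the whole aromatic group on the saturated ring carbon is now exchanged, whereas the earlier compounds varied only a group on an aromatic carbon of that phenyl. Furan-2-yl gives the same picture against all three earlier groups: 4-(dimethylamino)phenyl (a number 3 percentage points higher from compound 3 to compound 4 (within the scatter)), 4-methoxyphenyl (a number 4 percentage points lower from compound 2 to compound 4 (within the scatter)) and phenyl (a number 2 percentage points lower from compound 1 to compound 4 (within the scatter)), so among these compounds a five-membered aromatic ring with a hetero atom does not separate from a six-membered aromatic ring of carbon only. Nothing at hand explains why the read-out holds across these exchanges.

On these data alone, whether any group on this carbon can move the read-out beyond the scatter remains open. A cyclohexyl group, a longer alkyl chain or a phenyl bearing a carboxylic acid or a primary amine would test this.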